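From Nitrophenyl to Dichlorophenyl on a Triazole Nitrogen

The source may hold more compounds than are shown below. What is called first, only, known or untested is meant among the compounds shown, and "the series" means these compounds.

Compound 3 `N#CC1=C(N)Oc2c(N)cc3nc4ccccc4nc3c2C12C(=O)N(Cc1cnnn1-c1ccc([N+](=O)[O-])cc1)c1ccccc12` carries a 4-nitrophenyl group on an aromatic nitrogen of the shared core. In a functional assay on HCT-116 cells (Homo sapiens) for antiproliferative activity, read by MTT assay, with a stated time of 48 h (a higher number here means a weaker inhibitor, a lower number a stronger inhibitor), compound 3 reaches only a limit of the measurement, > 50000 nM, so no number is known for it. Compound 1 `N#CC1=C(N)Oc2c(N)cc3nc4ccccc4nc3c2C12C(=O)N(Cc1cnnn1-c1ccc(F)cc1)c1ccccc12`, which carries a 4-fluorophenyl group at the same place, likewise sits at a limit in this assay, > 50000 nM. Compound 2 `N#CC1=C(N)Oc2c(N)cc3nc4ccccc4nc3c2C12C(=O)N(Cc1cnnn1-c1cccc(Br)c1)c1ccccc12`, with a 3-bromophenyl group there, is the only one of the three with a number in this assay, 26100 nM. The step from the fluoro compound to the bromo compound was an at least 1.9-fold lower number from compound 1 to compound 2 (0.28 log units; that floor lies within the scatter), and the step on to the nitro compound was an at least 1.9-fold higher number from compound 2 to compound 3 (0.28 log units; that floor lies within the scatter); the direct step is a step that the two limits leave unreadable from compound 1 to compound 3. With the limit of > 50000 nM in this assay, at which 2 of the 3 values shown sit, the spread of this small set is largely unreadable.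

Compound 4 `N#CC1=C(N)Oc2c(N)cc3nc4ccccc4nc3c2C12C(=O)N(Cc1cnnn1-c1cc(Cl)ccc1Cl)c1ccccc12` is not yet measured. Its change from compound 3 is 2,5-dichlorophenyl in place of 4-nitrophenyl on an aromatic nitrogen. For the measured compounds named here, of the measured steps, the one from compound 2 to compound 3 bears most directly on it: there a halogenated phenyl was exchanged for the nitrophenyl and the number rose. The other halogenated phenyl, in compound 1, gave only a limit. A return to a halogenated phenyl is therefore expected to lower the number at most modestly. Compound 4 is expected at 25000 nM, within 8000 nM to 70000 nM. That would be an expected step of an at least 2.0-fold lower number from compound 3 to compound 4 (0.30 log units; that floor lies within the scatter), uncertain given the limits.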

Compound 4, half-maximal inhibitory concentration: > 50000 nM
Compound 4 was reported as a limit; the forecaster's own chance of this, stated with the estimate: 45%; middle value at least 2.0-fold (0.30 log units) away from the limit.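

In this assay compound 4 gives > 50000 nM, which is a limit of the measurement and not a number. For the compounds shown here, the one readable step, an at least 1.9-fold higher number from compound 2 to compound 4 (0.28 log units; that floor lies within the scatter), shows that a halogenated phenyl on this aromatic nitrogen does not by itself bring a compound into the measurable range, since the 2,5-dichlorophenyl group joins the 4-fluorophenyl group of compound 1 at the limit, while only the 3-bromophenyl group of compound 2 gives a number. The steps to compound 4 from compound 1 and from compound 3 cannot be read, because both ends of each are limits: the limit of > 50000 nM in this assay, at which 3 of the 4 values shown sit.

Going by these compounds alone, how far compound 1, compound 3 and compound 4 lie past the limit stays unknown, so these three cannot be ranked against one another, and the single number from compound 2 cannot show which feature of its group matters. A phenyl carrying an amine or a carboxylic acid, or a butyl chain in place of the phenyl, could show whether any group at this position gives a clearly lower number.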